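The source may report more compounds than this note shows. Statements on the series, on what has been measured and on what is new or still open speak of the compounds shown alone.

Compound 1 `Cc1cc(S(N)(=O)=O)ccc1NC(=O)COc1ccc(F)cc1Oc1ccc2ccccc2c1` is a sulfonamide-bearing amide whose aryl ether ends in a plain naphthalene. In an ADME assay on C8166 cells (Homo sapiens) for cytotoxicity, read by MTT assay (on this read-out lower numbers stand for higher toxicity in this test and higher numbers for lower toxicity in this test), compound 1 gives 68600 nM. Compound 2 `Cc1cc(S(N)(=O)=O)ccc1NC(=O)COc1ccc(F)cc1Oc1ccc2ccccc2c1Br` carries a bromine on that naphthalene, and in this assay compound 2 gives 39500 nM. Going by the values given here, the change a 1.7-fold lower number from compound 1 to compound 2 (0.24 log units; within the scatter) is the only measured step, and it stays within the scatter. Among the two measured numbers compound 2 has the lower one, but as the gap to compound 1 is within the scatter, no order between them can be read from this.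

Compound 3 `Cc1cc(S(N)(=O)=O)ccc1NC(=O)COc1ccc(F)cc1Oc1ccc2cc(C#N)ccc2c1` differs from compound 2 by 6-cyanonaphthalen-2-yl in place of 1-bromonaphthalen-2-yl on an oxygen on an aromatic ring: the bromine leaves and a nitrile appears elsewhere on the naphthalene. Among the compounds with values here, the one measured step bears on it only in part, since it shows that placing a bromine on this ring moved the number by a 1.7-fold lower number from compound 1 to compound 2 (0.24 log units; within the scatter), which is within the scatter. Within the data shown here, a nitrile on this ring has no measured precedent here. Among the measured compounds shown here, since the only known change on this ring stayed within the scatter, compound 3 is expected to stay close to compound 2, with an expected step of a 1.3-fold higher number from compound 2 to compound 3 (0.10 log units; within the scatter) that is not beyond the scatter. The estimate for compound 3 in this assay is 50000 nM, with a range from 20000 nM to 125000 nM.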

Compound 3, half-maximal cytotoxic concentration: > 395000 nM
Compound 3 ended at the assay's limit; the forecaster's own chance of this, stated with the estimate: 10%; middle value at least 7.9-fold (0.89 log units) from the limit.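

In this assay compound 3 gives > 395000 nM, which is a limit of the assay and not an exact number: the limit of > 395000 nM in this assay, at which 1 of the 3 values shown sits.

Unlike the bromine step, which stayed within the scatter, both steps that lead to the nitrile go beyond it: replacing the 1-bromonaphthalen-2-yl group with 6-cyanonaphthalen-2-yl gives an at least 10-fold higher number from compound 2 to compound 3 (1.00 log units; beyond the scatter), and placing the nitrile on the plain naphthalene gives an at least 5.7-fold higher number from compound 1 to compound 3 (0.76 log units; beyond the scatter). The group on this oxygen can therefore shift the number clearly towards lower toxicity in this test, which the first two compounds could not show.

The three compounds leave open whether this shift belongs to the nitrile itself or to where it sits on the naphthalene, and whether another group in its place, such as an amine or a carboxylic acid, would shift the number as far. Going by these compounds, with only a limit for compound 3, the full size of both steps also remains unknown.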